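The compounds below may be only part of what the source reports. "The series", "measured", "known", "first", "only" and "open" are said of these compounds alone.

Compound 1, `O=C(NCCCCC(c1ccc(F)cc1)c1ccc(F)cc1)Nc1cccc(Cl)c1`, and compound 2, `O=C(NCCCCC(c1ccc(F)cc1)c1ccc(F)cc1)Nc1ccc([N+](=O)[O-])c(C(F)(F)F)c1`, share the same core and differ only in the ring carried on one amide-type nitrogen. Both were tested in a functional assay on MDA-MB-231 cells (Homo sapiens) for cytotoxicity, read by MTT assay, with a stated time of 48 h; on this read-out lower numbers stand for stronger inhibition and higher numbers for weaker inhibition. In this assay compound 1 gives 5070 nM, the higher of the two numbers, while compound 2 gives 4550 nM; the two values lie within the usual scatter, so nothing separates them.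

Compound 3, `Cc1cc(Cl)ccc1NC(=O)NCCCCC(c1ccc(F)cc1)c1ccc(F)cc1`, has not yet been measured. It differs from compound 1 in one place: 4-chloro-2-methylphenyl in place of 3-chlorophenyl on an amide-type nitrogen. In compound 1 the 3-chlorophenyl group sits on an amide-type nitrogen whose other neighbour is a carbonyl carbon, and in compound 3 the 4-chloro-2-methylphenyl group takes that spot. Among the compounds with values here, no measured pair shows what such a change does here, so the expected step from compound 1 to compound 3 in this assay is none beyond the scatter, a 1.1-fold lower number from compound 1 to compound 3 (0.05 log units; within the scatter). On that basis compound 3 is estimated at 4500 nM, with a likely range from 1800 nM to 11000 nM.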

Compound 3, half-maximal inhibitory concentration: > 20000 nM
Compound 3 ended at the assay's limit (the forecaster's own chance of this, stated with the estimate: 5%); middle value at least 4.4-fold (0.64 log units) away from the limit.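

Within the data shown here, until this result, the ring on this amide-type nitrogen looked forgiving, since compound 1 and compound 2 carry different rings yet could not be told apart. Placing 4-chloro-2-methylphenyl in place of 3-chlorophenyl gives an at least 3.9-fold higher number from compound 1 to compound 3 (0.59 log units; beyond the scatter) in this assay, which shows that this position does respond to the ring it carries. Compound 3 stands at a limit of the assay, not at a number: the limit of > 20000 nM in this assay, at which 1 of the 3 values shown sits.

The change shifts the chlorine and adds a methyl in a single step, so the compounds shown cannot say which of the two accounts for the loss. Going by these compounds, a plain 4-chlorophenyl or 2-methylphenyl group on the same nitrogen would separate these two changes, and how large the true step is also stays open.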